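Carbamate in place of furanoyl-aminopropyl on the ring oxygen

A few compounds are considered here, and "the series" means these few. Any claim that something is new, unique, unknown or untested is made for them only; others in the source may bear on it.

Compound 3 `CC(C)=CCC/C(C)=C/CC1Cc2c(OCCCNC(=O)c3ccco3)cc(=O)n(CCCO)c2CC1(C)C` gives 2.8% in a functional assay on PANC-1 cells (Homo sapiens) for inhibition, read by MTT assay, with a stated time of 24 h, tested at 10 uM; on this read-out lower numbers stand for less inhibition and higher numbers for more inhibition at the one concentration tested (going by the name of the read-out); it stands second highest of the three numbers, with compound 1 `CC(C)=CCC/C(C)=C/CC1Cc2c(O)cc(=O)n(CCCO)c2CC1(C)C` at 0% within the scatter of it, and compound 2 `CC(C)=CCC/C(C)=C/CC1Cc2c(OCC=C(C)C)cc(=O)n(CCCO)c2CC1(C)C` at 15.9% beyond the scatter above it. The measured steps are a number 15.9 percentage points higher from compound 1 to compound 2 (beyond the scatter), a number 2.8 percentage points higher from compound 1 to compound 3 (within the scatter) and a number 13.1 percentage points lower from compound 2 to compound 3 (beyond the scatter). Compound 4 `COc1ccc(NC(=O)Oc2cc(=O)n(CCCO)c3c2CC(C/C=C(\C)CCC=C(C)C)C(C)(C)C3)cc1` differs from compound 3 by (4-methoxyphenyl)carbamoyl in place of 3-(((furan-2-yl)carbonyl)amino)propyl on an oxygen on an aromatic ring. For the measured compounds named here, no measured step changes a substituent on this oxygen into a carbamoyl group, so only the size of the earlier steps guides the expectation, and those that introduce a group with a carbonyl and an amide hydrogen stayed within the scatter. The expected step is a number 2.2 percentage points higher from compound 3 to compound 4 (within the scatter), with no change beyond the scatter. Compound 4 is estimated at 5%, within 0% to 20%.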

Compound 4, a percentage reported as inhibition, at one concentration (the size of the read-out at that concentration, not a potency): 0%
For compound 4 the middle estimate is 5 percentage points above the measured one; measured number inside the range.
By their numbers in this assay, from the lowest: compounds 1, 4 and 3 (each within the scatter of the next); then compound 2.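

On the oxygen on an aromatic ring, (4-methoxyphenyl)carbamoyl gives a read-out in this assay that cannot be told apart from the free hydroxyl (no change at the digits printed from compound 1 to compound 4 (within the scatter)) or from 3-(((furan-2-yl)carbonyl)amino)propyl (a number 2.8 percentage points lower from compound 3 to compound 4 (within the scatter)). A carbamoyl link on this oxygen therefore brings no gain here, and the 3-methylbut-2-en-1-yl ether keeps its separation (a number 15.9 percentage points lower from compound 2 to compound 4 (beyond the scatter)). No outside data bear on why these groups read as they do.

Open, as far as these compounds go, is whether a longer unbranched alkyl chain on this oxygen, such as octyl, would exceed the 3-methylbut-2-en-1-yl ether. Also open, from the compounds shown here alone, is how a carbamoyl carrying a plain alkyl group, such as ethylcarbamoyl, would compare.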